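Methoxy on the aromatic ring of compound 1

This account rests on a few compounds, and the source may have more. Where it says the series, first, only, none or still open, it means among the compounds named here.

Among the compounds with values here, compound 1 `COC1(c2ccccc2)Oc2ccccc2C(=O)C1(O)O` gives 19 ug/mL in a functional assay on KB cells (Homo sapiens) for cytotoxicity (a higher number here means that more compound is needed for the effect, a lower number that less compound is needed), the only number in the set. Compound 2 `CC(=O)Nc1c(-c2ccccc2)oc2ccccc2c1=O` reaches only the limit > 100 ug/mL in this assay. Compound 3 `Nc1c(-c2ccccc2)oc2ccccc2c1=O` likewise returns the limit > 100 ug/mL. The step that the two limits leave unreadable from compound 2 to compound 3 is therefore unreadable, both values sitting at the limit of > 100 ug/mL in this assay, at which 2 of the 3 values shown sit. Within the data shown here, compound 1 thus stands apart as the one compound with a readable value. Compound 4 `COc1ccc2c(c1)OC(OC)(c1ccccc1)C(O)(O)C2=O` differs from compound 1 by methoxy in place of hydrogen on an aromatic carbon. Among the measured compounds shown here, no measured step covers a change of this kind on this core; the single measured step is the unreadable one. The expectation is accordingly for compound 4 to stay near compound 1, with no step beyond scatter: no change at the digits printed from compound 1 to compound 4 (within the scatter) is the estimated step. Compound 4 is expected at 19 ug/mL, within 7 ug/mL to 50 ug/mL.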

Compound 4, concentration for half-maximal effect: 20 ug/mL
Compound 4: the middle estimate sits 1.1-fold (0.02 log units) below what was measured, and the stated range covers the measured number.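

Methoxy in place of hydrogen on an aromatic carbon, meta to a fused ring and para to a fused ring, gives a 1.1-fold higher number from compound 1 to compound 4 (0.02 log units; within the scatter) in this assay. Within the data shown here, this is the first readable step, and it shows that this position of the shared core carries methoxy with no step beyond the scatter. Nothing shown gives a reason for this result.

Going by these compounds, whether an amine, a carboxylic acid or a longer chain such as butoxy at this position would leave the read-out equally unmoved stays open. Also open, on these data alone, is how substitution at the other positions of the shared core would read.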